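Aryl swap on the isoxazoline carbon: fluorophenyl analogue

This account rests on a few compounds, and the source may have more. Where it says the series, first, only, none or still open, it means among the compounds named here.

Two compounds of the series have a number in a physicochemical assay for lipophilicity; a higher number here means a more lipophilic compound, a lower number a more polar compound. Compound 1 `C[C@H]1CC[C@@H]2[C@@H](OC(=O)[C@]23CC(c2ccc([N+](=O)[O-])cc2)=NO3)[C@]2(C)C(=O)C=C[C@@]12O` gives 1.37. Compound 2 `COc1ccc(C2=NO[C@]3(C2)C(=O)O[C@@H]2[C@H]3CC[C@H](C)[C@]3(O)C=CC(=O)[C@@]23C)cc1OC` gives 1.06, the lowest of the two; its nearest neighbour is compound 1, and the step of a number 0.31 log units lower from compound 1 to compound 2 (beyond the scatter) is beyond the scatter.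

Compound 3 `C[C@H]1CC[C@@H]2[C@@H](OC(=O)[C@]23CC(c2ccc(F)cc2)=NO3)[C@]2(C)C(=O)C=C[C@@]12O` is not yet measured in this assay. It differs from compound 2 in one place: 4-fluorophenyl in place of 3,4-dimethoxyphenyl on a carbon with a double bond to nitrogen.

Among the compounds with values here, the only measured step that bears on this change is the one from compound 1 to compound 2, in which the aryl group on the carbon with a double bond to nitrogen was exchanged and the number fell by a number 0.31 log units lower from compound 1 to compound 2 (beyond the scatter). Compound 3 undoes the entry of the 3,4-dimethoxyphenyl group and puts in a 4-fluorophenyl group instead, so a step of comparable size in the opposite direction is expected, a number 0.49 log units higher from compound 2 to compound 3 (beyond the scatter), placing compound 3 at or somewhat above compound 1. Compound 3 is therefore estimated at 1.55, with a range from 1.15 to 1.95.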

Compound 3, partition coefficient: 1.58
Compound 3: middle estimate off by 0.03 log units, on the low side; low and high end bracket the measured number.
By their numbers in this assay, from the lowest: compound 2; then compounds 1 and 3 (each within the scatter of the next).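

In this assay, a second exchange of the aryl group on the carbon with a double bond to nitrogen moves the number, as 4-fluorophenyl in place of 3,4-dimethoxyphenyl gives a number 0.52 log units higher from compound 2 to compound 3 (beyond the scatter) and thus runs opposite to the earlier step, a number 0.31 log units lower from compound 1 to compound 2 (beyond the scatter) for the 3,4-dimethoxyphenyl group. Fluoro in place of nitro on an aromatic carbon gives a number 0.21 log units higher from compound 1 to compound 3 (within the scatter) and so does not separate compound 1 from compound 3, which leaves compound 2 alone at the low end of these three, with two different 4-substituted phenyl groups standing together against the 3,4-dimethoxyphenyl group. Nothing at hand accounts for the size or direction of these steps.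

The compounds shown leave open whether both methoxy groups are needed for the low number of compound 2, since a phenyl ring with a single methoxy group or with no substituent at all would be required to divide the step. Going by these compounds, how this position responds to an amine or a carboxylic acid on the aryl ring, or to a saturated ring in place of the aryl group, also remains open.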